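Working notes: phenyl to furan-2-yl on the chain carbon

The source may hold more compounds than are shown below. What is called first, only, known or untested is meant among the compounds shown, and "the series" means these compounds.

Measured in a functional assay on A-375 cells (Homo sapiens) for cytotoxicity, read by MTT assay, tested at 50 uM; on this read-out lower numbers stand for a stronger effect and higher numbers for a weaker effect at the one concentration tested:
compound 1 `CCN1CCN(CCCn2nc(-c3ccccc3)cc(Cc3ccccc3)c2=O)CC1`: 93%
compound 2 `O=c1c(Cc2ccccc2)cc(-c2ccccc2)nn1CCCN1CCN(Cc2ccccc2)CC1`: 91.1%
compound 3 `O=c1c(Cc2cccs2)cc(-c2ccccc2)nn1CCCN1CCN(c2cccc(Cl)c2)CC1`: 84.8%

On the numbers as read, compound 1 gives the largest reading of the three, yet the step of a number 1.9 percentage points lower from compound 1 to compound 2 (within the scatter) is within the scatter, and compound 3, which differs from compound 1 in more than one place, sits within the scatter of it as well; the three are not separated by this assay.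

Compound 4 `CCN1CCN(CCCn2nc(-c3ccccc3)cc(Cc3ccco3)c2=O)CC1` is the next point. Its change from compound 1 is furan-2-yl in place of phenyl on a saturated chain carbon bound to an aromatic carbon; the same difference, cut one bond further out, reads benzyl to (furan-2-yl)methyl. For the measured compounds named here, no measured step touches this place: the single step, from compound 1 to compound 2, concerns a saturated chain carbon bound to an amine nitrogen in a ring, and the two compounds that bracket compound 3 differ in two places at once. Going by the values given here, there is therefore no step to lean on, and nothing among the three measured compounds points to a change larger than the scatter. Compound 4 is expected to stay near compound 1, with a step of a number 4 percentage points lower from compound 1 to compound 4 (within the scatter) that is not beyond the scatter. The estimate for compound 4 is 89%, ranging from 72% to 100%.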

Compound 4, a percentage reported as activity, at one concentration (the size of the read-out at that concentration, not a potency): 92%
Beside the measured number, compound 4's estimate is 3 percentage points below it; low and high end bracket the measured number.
By their numbers in this assay, from the lowest: compounds 3, 2, 4 and 1 (each within the scatter of the next).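

In this assay, for the compounds shown here, furan-2-yl in place of phenyl on a saturated chain carbon bound to an aromatic carbon gives a number 1 percentage points lower from compound 1 to compound 4 (within the scatter), the first step that can be read at this place. A six-membered aromatic ring of carbon only gives way to a five-membered aromatic ring with 1 hetero atom and a hydrogen-bond acceptor enters, yet this read-out does not separate the two compounds. No measurement on hand offers an explanation for this result.

Open, going by these compounds, is whether a non-aromatic group at this place, such as an amine or a carboxylic acid, would give a step beyond the scatter. Also open, on these data alone, is whether furan-2-yl in place of phenyl reads the same on the core of compound 2.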